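Adding an Ethoxy Group to Compound 2

The source may hold more compounds than are shown below. What is called first, only, known or untested is meant among the compounds shown, and "the series" means these compounds.

Compound 1 `Cc1ccc(S(=O)(=O)Nc2ccc3c[nH]nc3c2)cc1` carries a hydrogen on its aromatic nitrogen. In a functional assay on A549 cells (Homo sapiens) for cytotoxicity, read by MTT assay, with a stated time of 72 h (on this read-out lower numbers stand for stronger inhibition and higher numbers for weaker inhibition), compound 1 reaches only a limit, > 100000 nM. Among the measured compounds shown here, compound 2 `C=CCn1cc2ccc(NS(=O)(=O)c3ccc(C)cc3)cc2n1`, which carries an allyl in that place, in this assay gives 11900 nM, the only measured number in this set. For the measured compounds named here, the step of an at least 8.4-fold lower number from compound 1 to compound 2 (0.92 log units; beyond the scatter) is the single measured step available. Compound 3 `C=CCn1cc2ccc(NS(=O)(=O)c3ccc(C)cc3)c(OCC)c2n1` differs from compound 2 by ethoxy in place of hydrogen on an aromatic carbon. Going by the values given here, no measured step involves a change on an aromatic carbon, so the one measured step, which concerned an aromatic nitrogen, offers no direct guide to this change. With nothing pointing either way, the expected step is a 1.2-fold lower number from compound 2 to compound 3 (0.08 log units; within the scatter), a change within the usual scatter. Compound 3 is therefore estimated at 10000 nM, with a range from 3000 nM to 40000 nM.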

Compound 3, half-maximal inhibitory concentration: > 100000 nM
Compound 3: a limit, no number; the forecaster's own chance of this, stated with the estimate: 10%; middle value at least 10-fold (1.00 log units) from the limit.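

The ethoxy group on this aromatic carbon, ortho to a large group, is not a neutral change: in this assay it brings an at least 8.4-fold higher number from compound 2 to compound 3 (0.92 log units; beyond the scatter) and so moves the number the opposite way from the allyl step on the aromatic nitrogen. Among the compounds shown here, the earlier compounds differed only at that nitrogen, so this is the first sign that this carbon position also matters for the read-out. For compound 3 the value is a limit and not a number, so the step gives only a minimum size: the limit of > 100000 nM in this assay, at which 2 of the 3 values shown sit.

On these data alone, whether any group at this position has the same effect, or whether it depends on ethoxy itself, stays open. A smaller methoxy, a fluorine atom or an amine at the same carbon would help to separate these two readings.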